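Swapping acetyl for dimethylamino on a cytotoxic pyrazole series

The source may hold more compounds than are shown below. What is called first, only, known or untested is meant among the compounds shown, and "the series" means these compounds.

Measured compounds:
Compound 1 `COc1cc(C)cc(-c2c(-c3ccnc(-c4ccc(C(C)=O)cc4)c3)cnn2CC#N)c1`, 84%
Compound 2 `COc1cc(C)cc(-c2nn(CC#N)cc2-c2ccnc(-c3ccc(N(C)C)cc3)c2)c1`, 24%

In a functional assay on CCRF-CEM cells (Homo sapiens) for cytotoxicity, read by sulforhodamine B assay, with a stated time of 48 h, tested at 100 nM (on this read-out higher numbers stand for a weaker effect at the one concentration tested and lower numbers for a stronger effect), compound 1 gives 84%, the highest of the two numbers, while compound 2 gives 24%, a gap beyond the scatter. Compound 3 `COc1cc(C)cc(-c2c(-c3ccnc(-c4ccc(N(C)C)cc4)c3)cnn2CC#N)c1` is not yet measured; it differs from compound 1 by dimethylamino in place of acetyl on an aromatic carbon. Within the data shown here, no step between measured compounds is available for this change, yet a sizable move toward a stronger effect is expected because compound 2 gives 24% while carrying dimethylamino. The expected step is a number 49 percentage points lower from compound 1 to compound 3 (beyond the scatter). Compound 3 is therefore estimated at 35%, within 12% to 65%.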

Compound 3, a percentage reported as activity, at one concentration (the size of the read-out at that concentration, not a potency): 11%
Compound 3: the middle estimate sits 24 percentage points above what was measured, and the stated range ends above it.
By their numbers in this assay, from the lowest: compound 3; then compound 2; then compound 1.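

In this assay, among these compounds, the change from 4-acetylphenyl to 4-(dimethylamino)phenyl gives a number 73 percentage points lower from compound 1 to compound 3 (beyond the scatter) and so is a large step, read directly on one core for the first time. This position therefore responds strongly to the group it carries, even though both groups have the same count of heavy atoms and neither has a donor. No measurement shown here accounts for the step. From the compounds shown here alone, whether a morpholine ring, a primary amine or a carboxylic acid at this place would keep or lose the effect remains open.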